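A few compounds are considered here, and "the series" means these few. Any claim that something is new, unique, unknown or untested is made for them only; others in the source may bear on it.

Compound 1 `COc1ccc(/C=C/C(=O)CC(C)=O)cc1OC`: 4700 nM
Compound 2 `COc1ccc(/C=C/C(=O)CC(C)=O)cc1`: 11900 nM
Compound 3 `COc1cc(/C=C/C(=O)CC(C)=O)cc(OC)c1O`: 24700 nM

All three were measured in a functional assay on HCT-116 cells (Homo sapiens) for antiproliferative activity, read by MTT assay, with a stated time of 72 h; a lower number here means a stronger inhibitor, a higher number a weaker inhibitor. Compound 2 has the middle number of the three, with compound 1 lower and compound 3 higher, both gaps beyond the scatter. Compound 4 `CC(=O)CC(=O)/C=C/c1ccc(O)cc1` differs from compound 2 by one change, methoxy to hydroxy: hydrogen in place of methyl on an oxygen on an aromatic ring. Going by the values given here, no measured step makes this exact change. The nearest guide is a 2.5-fold higher number from compound 1 to compound 2 (0.40 log units; beyond the scatter), where a methoxy is lost altogether. Among the compounds with values here, compound 3, the only measured compound with a hydroxy, gives 24700 nM, but it differs from compound 2 in more than one place. A modest rise in the number is therefore expected, though it may stay within the scatter. The expected change is a 1.3-fold higher number from compound 2 to compound 4 (0.10 log units; within the scatter). For compound 4 the estimated value is 15000 nM, with an expected range of 6000 nM to 35000 nM.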

Compound 4, half-maximal inhibitory concentration: 36000 nM
The estimate for compound 4 lay 2.4-fold (0.38 log units) below the measured number; the measured number lies above the stated range.
By their numbers in this assay, from the lowest: compound 1; then compound 2; then compounds 3 and 4 (each within the scatter of the next).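

In this assay, replacing the methyl on this aromatic oxygen with hydrogen gives a 3.0-fold higher number from compound 2 to compound 4 (0.48 log units; beyond the scatter), so even this small change at the oxygen matters. Going by these compounds alone, until now, the only measured single change was the loss of a whole methoxy group elsewhere on the ring, and this new step moves the number in the same direction. Nothing available explains why the free hydroxy gives the weaker result. Still open, going by these compounds, is how a longer chain on this oxygen, such as ethoxy, would behave, or an amine in place of the hydroxy.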